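This account rests on a few compounds, and the source may have more. Where it says the series, first, only, none or still open, it means among the compounds named here.

Measured so far in a functional assay on HeLa S3 cells (Homo sapiens) for antiproliferative activity, read by XTT assay, with a stated time of 72 h; on this read-out lower numbers stand for stronger inhibition and higher numbers for weaker inhibition:
compound 1 `COc1ncnc2c1c(-c1cccs1)cn2[C@@H]1O[C@H](CO)[C@@H](O)[C@H]1O` — 1760 nM
compound 2 `CNc1ncnc2c1c(-c1cccs1)cn2[C@@H]1O[C@H](CO)[C@@H](O)[C@H]1O` — only a limit, > 20000 nM
compound 3 `CSc1ncnc2c1c(-c1cccs1)cn2[C@@H]1O[C@H](CO)[C@@H](O)[C@H]1O` — 1960 nM

Compound 1 gives the lowest of the two numbers, but its gap to compound 3, a 1.1-fold higher number from compound 1 to compound 3 (0.05 log units; within the scatter), stays within the scatter. For compound 2 the read-out is a limit (the limit of > 20000 nM in this assay, at which 1 of the 3 values shown sits). The step of an at least 11-fold higher number from compound 1 to compound 2 (1.05 log units; beyond the scatter) is large, as is an at least 10-fold lower number from compound 2 to compound 3 (1.00 log units; beyond the scatter). All three measured steps vary the group on the aromatic carbon that carries methoxy, methylamino or methylsulfanyl; none touches the thiophen-2-yl.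

Compound 4 `COc1ncnc2c1c(-c1cc3ccccc3o1)cn2[C@@H]1O[C@H](CO)[C@@H](O)[C@H]1O` differs from compound 1 by 1-benzofuran-2-yl in place of thiophen-2-yl on an aromatic carbon. Among the compounds with values here, no measured step bears on this change, so its size cannot be read from the series; the methoxy of compound 1 is kept. The estimate therefore rests on compound 1 and its 1760 nM, with a wide range in both directions. Compound 4 is expected to give 600 nM, between 100 nM and 5000 nM. The expected step of a 2.9-fold lower number from compound 1 to compound 4 (0.47 log units; beyond the scatter) is set modestly toward a lower number.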

Compound 4, half-maximal inhibitory concentration: 9240 nM
The estimate for compound 4 lay 15-fold (1.19 log units) below the measured number; the whole stated range lies below it.
By their numbers in this assay, from the lowest: compounds 1 and 3 (each within the scatter of the next); then compound 4. At a limit, above all of these: compound 2.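

In this assay, the aromatic carbon that carries thiophen-2-yl in compounds 1 to 3 now proves open to change in the read-out: the step is a 5.3-fold higher number from compound 1 to compound 4 (0.72 log units; beyond the scatter) with the methoxy kept. The series therefore responds at this second place as well as at the carbon bearing methoxy, methylamino or methylsulfanyl, and adding a six-membered aromatic ring of carbon with oxygen in place of sulfur does not give a lower number. Nothing measured here explains this step.

Open, from the compounds shown here alone, is which part of the exchange matters, the added ring or the ring hetero atom; furan-2-yl and 1-benzothiophen-2-yl would separate the two. Also open, going by these compounds, is whether 1-benzofuran-2-yl gives a similar step alongside methylsulfanyl, as in compound 3.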